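The compounds below may be only part of what the source reports. "The series", "measured", "known", "first", "only" and "open" are said of these compounds alone.

Measured compounds in a functional assay on KYSE-410 cells (Homo sapiens) for antiproliferative activity, read by MTT assay, with a stated time of 72 h; on this read-out higher numbers stand for weaker inhibition and lower numbers for stronger inhibition:
Compound 1, `COc1ccc(NC(=O)c2cc(=O)[nH]c3cc(Br)ccc23)cc1`: here compound 1 reaches only the limit > 20000 nM.
Compound 2, `O=C(Nc1ccc(C(F)(F)F)cc1)c1cc(=O)[nH]c2cc(Br)ccc12`: here compound 2 reaches only the limit > 20000 nM.
Compound 3, `COc1cccc(NC(=O)c2cc(=O)[nH]c3cc(Br)ccc23)c1`: here compound 3 reaches only the limit > 20000 nM.

Each of these values is a limit of the assay and not a number. The change from compound 1 to compound 2 is trifluoromethyl in place of methoxy on an aromatic carbon, and it gives a step that the two limits leave unreadable from compound 1 to compound 2. The cores of compound 1 and compound 3 hold the same atoms joined differently; the difference between the two cores is not broken down here. Compound 4, `O=C(Nc1cccc(C(F)(F)F)c1)c1cc(=O)[nH]c2cc(Br)ccc12`, is not yet measured and differs from compound 3 by trifluoromethyl in place of methoxy on an aromatic carbon. This is the same kind of change as from compound 1 to compound 2, but the place is not identical: para to a large group there, meta to a large group here. Every value shown sits at the limit of > 20000 nM in this assay, at which 3 of the 3 values shown sit, so the earlier step carries no readable size. In this assay the step from compound 3 to compound 4 is expected to be a step that the limit leaves unreadable from compound 3 to compound 4. That expectation rests on compound 3 standing at its limit > 20000 nM. It rests also on the unreadable a step that the two limits leave unreadable from compound 1 to compound 2. Compound 4 is estimated at 30000 nM, within a range from 12000 nM to 100000 nM, and most likely the assay will again report only a limit.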

Compound 4, half-maximal inhibitory concentration: > 20000 nM
Compound 4 ended at the assay's limit (the forecaster's own chance of this, stated with the estimate: 80%); the middle value does not contradict the limit.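

In this assay compound 4 gives > 20000 nM, which is a limit and not a number. No step can be read between compound 3 and compound 4, because both stand at the same limit: the limit of > 20000 nM in this assay, at which 4 of the 4 values shown sit.

The compounds shown leave open how the four rank against one another, and whether trifluoromethyl in place of methoxy changes antiproliferative activity at all.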